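Ring nitrogen enters the trifluoromethyl aryl of compound 3

This account rests on a few compounds, and the source may have more. Where it says the series, first, only, none or still open, it means among the compounds named here.

This account concerns a small series of spirocyclic amides tested in an assay on membranes from liver for displacement of a labelled ligand from Glucagon receptor (Mus musculus), read by scintillation counting, with a stated time of 60 min; on this read-out lower numbers stand for stronger inhibition and higher numbers for weaker inhibition. Compound 1 `CC(C)(C)CC[C@H](c1ccc(C(=O)NCc2nn[nH]n2)cc1)N1C(=O)C(c2cncc(Cl)c2)=N[C@]12CC[C@@H](C(C)(C)C)CC2` gives 84 nM. Compound 2 `CC(C)(C)CC[C@H](c1ccc(C(=O)NCc2nn[nH]n2)cc1)N1C(=O)C(c2cccc(C(F)(F)F)c2)=N[C@]12CC[C@@H](C(C)(C)C)CC2` gives 140 nM, and compound 3 `CC(C)(C)CC[C@H](c1ccc(C(=O)NCc2nn[nH]n2)cc1)N1C(=O)C(c2ccc(C(F)(F)F)cc2)=N[C@]12CC[C@@H](C(C)(C)C)CC2` gives 190 nM, the highest of the three numbers; it sits close to compound 2, since the step of a 1.4-fold higher number from compound 2 to compound 3 (0.13 log units; within the scatter) is within the scatter, and furthest from compound 1, since the step of a 2.3-fold higher number from compound 1 to compound 3 (0.35 log units; beyond the scatter) is beyond it.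

Compound 4 `CC(C)(C)CC[C@H](c1ccc(C(=O)NCc2nn[nH]n2)cc1)N1C(=O)C(c2cnccc2C(F)(F)F)=N[C@]12CC[C@@H](C(C)(C)C)CC2` differs from compound 3 in one place: 4-(trifluoromethyl)pyridin-3-yl in place of 4-(trifluoromethyl)phenyl on a carbon with a double bond to nitrogen. For the measured compounds named here, no measured step isolates this exchange of a phenyl for a pyridinyl ring while keeping the trifluoromethyl group. Going by the values given here, the nearest guides are a 1.7-fold higher number from compound 1 to compound 2 (0.22 log units; within the scatter) and a 2.3-fold higher number from compound 1 to compound 3 (0.35 log units; beyond the scatter), where the only ring-nitrogen-bearing group gives the lowest number, but each of those steps also moves the substituent, so they bear only loosely here.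

The step of a 1.5-fold lower number from compound 3 to compound 4 (0.16 log units; within the scatter) is therefore expected to be small, within the scatter or a modest drop in number. Compound 4 is estimated at 130 nM in this assay, with a range from 50 nM to 400 nM.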

Compound 4, half-maximal inhibitory concentration: 96 nM
Compound 4: the middle estimate sits 1.4-fold (0.13 log units) above what was measured; measured number inside the range.
By their numbers in this assay, from the lowest: compounds 1, 4, 2 and 3 (each within the scatter of the next, the first and the last beyond it).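

The exchange of the phenyl ring for a pyridinyl ring, with the trifluoromethyl group kept, can now be read directly at this position on the carbon with a double bond to nitrogen: in this assay the step is a 2.0-fold lower number from compound 3 to compound 4 (0.30 log units; within the scatter), so the added ring nitrogen gives no change that can be told from scatter. The other two steps, a 1.5-fold lower number from compound 2 to compound 4 (0.16 log units; within the scatter) and a 1.1-fold higher number from compound 1 to compound 4 (0.06 log units; within the scatter), also stay within the scatter, so compound 4 cannot be separated from either compound, even though compound 1 and compound 3 stand apart. Nothing given here explains these numbers, and no cause can be assigned to them.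

The shown compounds leave open whether a methoxy group or a nitrile in place of the trifluoromethyl group on this pyridinyl ring would shift the number. A pyrimidine ring, with a second ring nitrogen, also remains an open case.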